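The compounds below may be only part of what the source reports. "The series", "measured", "known", "first", "only" and "open" are said of these compounds alone.

Compound 1 `Cc1ccc(-c2ccc(C)n2-c2ccc(-c3nc4ccc(F)cc4s3)cc2)cc1`, compound 2 `Cc1ccc(-c2ccc(F)cc2)n1-c1ccc(-c2nc3ccc(F)cc3s2)cc1` and compound 3 `COc1ccc(-c2ccc(C)n2-c2ccc(-c3nc4ccc(F)cc4s3)cc2)cc1` share one core and were examined in a functional assay on MCF7 cells (Homo sapiens) for cytotoxicity, read by sulforhodamine B assay, with a stated time of 48 h; a higher number here means a weaker inhibitor of growth, a lower number a stronger inhibitor of growth. In this assay compound 1 gives 2150 nM, compound 2 gives 1790 nM and compound 3 gives 2120 nM. Compound 1 differs from compound 2 by methyl in place of fluoro on an aromatic carbon, which gave a 1.2-fold lower number from compound 1 to compound 2 (0.08 log units; within the scatter). Compound 3 differs from compound 2 by methoxy in place of fluoro on an aromatic carbon, and this made a 1.2-fold higher number from compound 2 to compound 3 (0.07 log units; within the scatter). Compound 4 `COc1ccc2nc(-c3ccc(-n4c(C)ccc4-c4ccc(C)cc4)cc3)sc2c1` has not been measured; it differs from compound 1 by methoxy in place of fluoro on an aromatic carbon, the same kind of change, but here the place is part of a fused or bridged system of two rings, meta to a fused ring and para to a fused ring, rather than para to a large group. Since the earlier step read a 1.2-fold higher number from compound 2 to compound 3 (0.07 log units; within the scatter), for compound 4 in this assay a step of a 1.1-fold lower number from compound 1 to compound 4 (0.03 log units; within the scatter) is expected. Compound 4 is therefore estimated at 2000 nM, between 1000 nM and 4500 nM.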

Compound 4, concentration for 50% growth inhibition: 2570 nM
Beside the measured number, compound 4's estimate is 1.3-fold (0.11 log units) below it; the measured number falls inside the stated range.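

In this assay, methoxy in place of fluoro on the fused system of two rings gave a 1.2-fold higher number from compound 1 to compound 4 (0.08 log units; within the scatter). Set beside the earlier case, the same exchange reads alike on the two cores: the same change on two cores in this assay, a 1.2-fold higher number (0.07 log units; within the scatter) from compound 2 to compound 3 and a 1.2-fold higher number (0.08 log units; within the scatter) from compound 1 to compound 4, 1.0-fold (0.00 log units) apart, within the scatter of two such steps. For the compounds shown here, both steps lie within the scatter, so this shows only that the exchange left no readable mark on either core; it does not show a real effect of the same size carried from one core to the other, and two cases set no rule for the series.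

The compounds shown leave open whether an amine, a carboxylic acid or a longer chain on this aromatic carbon would move the number beyond the scatter.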